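The compounds below may be only part of what the source reports. "The series", "measured", "known", "first", "only" and "open" are said of these compounds alone.

Measured so far:
- compound 1 `CCOC(=O)C12C(=O)OCC=C1COC2c1ccc(F)cc1`: in a functional assay on HeLa cells (Homo sapiens) for cytotoxicity, read by MTT assay (on this read-out lower numbers stand for stronger inhibition and higher numbers for weaker inhibition), compound 1 gives 22900 nM
- compound 2 `CCOC(=O)C12C(=O)OCC=C1COC2c1ccc(Cl)cc1`: in this assay compound 2 gives 118000 nM
- compound 3 `CCOC(=O)C12C(=O)OCC=C1COC2c1ccc(N(C)C)cc1`: in this assay compound 3 gives 23400 nM

Compound 3 stands second highest of these three numbers. Its value and that of compound 1 lie within the usual scatter of each other, as the step of a 1.0-fold higher number from compound 1 to compound 3 (0.01 log units; within the scatter) shows, so the two cannot be told apart. Compound 2 sits clearly apart: the step of a 5.0-fold lower number from compound 2 to compound 3 (0.70 log units; beyond the scatter) is a modest but real drop in the number, meaning stronger inhibition for compound 3 than for compound 2.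

Compound 4 `CCOC(=O)C12C(=O)OCC=C1COC2c1ccc([N+](=O)[O-])cc1` differs from compound 3 in one place: nitro in place of dimethylamino on an aromatic carbon. The measured steps that touch this position are the two that lead into the dimethylamino group, a 1.0-fold higher number from compound 1 to compound 3 (0.01 log units; within the scatter) and a 5.0-fold lower number from compound 2 to compound 3 (0.70 log units; beyond the scatter). Among the measured compounds shown here, neither involves a nitro group, so they give only an indirect guide: across three different groups at this position the numbers have moved within a modest span, and no step has been large. For this assay the expected step is therefore small, possibly within the scatter, with no clear direction, a 1.3-fold higher number from compound 3 to compound 4 (0.11 log units; within the scatter). Compound 4 is estimated to give 30000 nM, with a likely range from 8000 nM to 120000 nM.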

Compound 4, half-maximal inhibitory concentration: 53400 nM
For compound 4 the middle estimate is 1.8-fold (0.25 log units) below the measured one; the measured number falls inside the stated range.
By their numbers in this assay, from the lowest: compounds 1 and 3 (each within the scatter of the next); then compound 4; then compound 2.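

In this assay, the nitro group gives this position a third level rather than matching either earlier one: there is a 2.3-fold higher number from compound 3 to compound 4 (0.36 log units; beyond the scatter) and a 2.3-fold higher number from compound 1 to compound 4 (0.37 log units; beyond the scatter), but also a 2.2-fold lower number from compound 2 to compound 4 (0.34 log units; beyond the scatter). Until now, the three groups fell into just two levels, with fluoro and dimethylamino indistinguishable and chloro apart from them, whereas nitro is separated from all three by steps beyond the scatter, though each of these steps is only modest. The position therefore distinguishes more finely among groups than the earlier compounds could show, but nothing available explains why the four groups fall in this order.

Going by these compounds, whether this position can produce a large step remains open, since a carboxylic acid, a primary amine or a longer carbon chain at this aromatic carbon could extend the span or fall inside it. The compounds shown also differ only at this one place, so they leave open how changes elsewhere on the shared core, such as to the ethyl ester, would affect the number.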